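Cytotoxicity on hamster fibroblasts in a quinolone series

The compounds below may be only part of what the source reports. "The series", "measured", "known", "first", "only" and "open" are said of these compounds alone.

Measured compounds:
compound 1 `CCNCC1CCN(c2c(F)cc3c(=O)c(C(=O)O)cn(CC)c3c2F)C1` 160 ug/mL
compound 2 `CCn1cc(C(=O)O)c(=O)c2cc(F)c(N3CCC(N)C3)c(F)c21` 300 ug/mL
compound 3 `Nc1c(F)c(N2CCC(N)C2)cc2c1c(=O)c(C(=O)O)cn2C1CC1` 54 ug/mL

In a functional assay on V79 cells (Cricetulus griseus) for cytotoxicity, read by colony formation (on this read-out higher numbers stand for weaker inhibition and lower numbers for stronger inhibition), compound 2 gives 300 ug/mL and compound 1 gives 160 ug/mL. The change between them, ((ethylamino)methyl in place of amino on a saturated ring carbon), gave a step of a 1.9-fold lower number from compound 2 to compound 1 (0.27 log units; within the scatter); the two numbers lie within the usual scatter, so no order between compound 1 and compound 2 is claimed. Compound 3 gives 54 ug/mL, the lowest number of the three, and its steps to compound 1 and compound 2 both lie beyond the scatter. The difference between the core of compound 3 and the core of compound 2 is not broken down here.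

Compound 4 `CCNCC1CCN(c2cc3c(c(N)c2F)c(=O)c(C(=O)O)cn3C2CC2)C1` is not yet measured in this assay. It carries the change ((ethylamino)methyl in place of amino on a saturated ring carbon), the same change as from compound 2 to compound 1. On the core of compound 2 this change gave a step of a 1.9-fold lower number from compound 2 to compound 1 (0.27 log units; within the scatter). The same kind of step is expected on the core of compound 3: an estimated 1.5-fold lower number from compound 3 to compound 4 (0.19 log units; within the scatter), resting on one pair only. For compound 4 the expected value is 35 ug/mL, between 15 ug/mL and 90 ug/mL.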

Compound 4, half-maximal inhibitory concentration: 61 ug/mL
Compound 4: the middle estimate sits 1.7-fold (0.24 log units) below what was measured; the range from low to high includes it.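

In this assay, amino gives way to (ethylamino)methyl on a saturated ring carbon with a step of a 1.1-fold higher number from compound 3 to compound 4 (0.05 log units; within the scatter), so no order is claimed within this pair. Set beside the earlier pair, the change reads the same on both cores, and the two steps cannot be told apart: the same change on two cores in this assay, a 1.9-fold lower number (0.27 log units; within the scatter) from compound 2 to compound 1 and a 1.1-fold higher number (0.05 log units; within the scatter) from compound 3 to compound 4, 2.1-fold (0.33 log units) apart, within the scatter of two such steps

On these two pairs, then, the change moves the number by no more than the scatter on either core, but this rests on two pairs only and does not show that the change would stay as small on a third core.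

Still open, on these data alone, is how the read-out responds to other groups on that saturated ring carbon, such as a hydroxyl, a dimethylamino group or a longer chain such as (propylamino)methyl. Also open is which of the places where the cores differ accounts for the lower numbers seen with the core of compound 3.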